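The source may hold more compounds than are shown below. What is called first, only, known or untested is meant among the compounds shown, and "the series" means these compounds.

Measured compounds:
- compound 1 `COc1cc(F)c(CN2C(=O)N(c3ccc(OC)c(OC)c3)S(=O)(=O)c3ccccc32)c(F)c1` gives 0.501 nM in an assay on HEK293 cells for displacement of a labelled ligand from Orexin receptor type 2 (Homo sapiens), read by scintillation counting, with a stated time of 90 min; a higher number here means a weaker inhibitor, a lower number a stronger inhibitor
- compound 2 `COc1ccc(N2C(=O)N(Cc3c(F)cccc3Cl)c3ccccc3S2(=O)=O)cc1OC` gives 0.794 nM
- compound 3 `COc1cc(N2C(=O)N(Cc3c(F)cc(F)cc3Cl)c3ccccc3S2(=O)=O)cnc1OC` gives 1.59 nM

Compound 2 stands second highest of the three numbers, with compound 1 nearest and compound 3 furthest, both within the scatter. Compound 4 `COc1ccc(N2C(=O)N(Cc3c(F)cc(F)cc3OC)c3ccccc3S2(=O)=O)cc1OC` is not yet measured; it carries 2,4-difluoro-6-methoxyphenyl in place of 2-chloro-6-fluorophenyl on a saturated chain carbon bound to an amide-type nitrogen in a ring. Going by the values given here, the only measured step at the same place is a 1.6-fold higher number from compound 1 to compound 2 (0.20 log units; within the scatter), which exchanged one substituted benzyl for another without moving beyond the scatter. Compound 3, the other difluorinated benzyl, differs from compound 2 in two places and cannot be read as a single step; its value sits close to compound 2 anyway. No step beyond the scatter is therefore expected in this assay. Compound 4 is estimated at 0.8 nM, range 0.3 nM to 2.5 nM, a step of a 1.0-fold higher number from compound 2 to compound 4 (0.00 log units; within the scatter).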

Compound 4, inhibition constant: 6.31 nM
The estimate for compound 4 lay 7.9-fold (0.90 log units) below the measured number; the whole stated range lies below it.
By their numbers in this assay, from the lowest: compounds 1, 2 and 3 (each within the scatter of the next, the first and the last beyond it); then compound 4.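

In this assay the place on a saturated chain carbon bound to an amide-type nitrogen in a ring proves sensitive to the exact substituted phenyl, as a 7.9-fold higher number from compound 2 to compound 4 (0.90 log units; beyond the scatter) and a 13-fold higher number from compound 1 to compound 4 (1.10 log units; beyond the scatter) both lie beyond the scatter, unlike the earlier step there. The second of these exchanges 2,6-difluoro-4-methoxyphenyl for 2,4-difluoro-6-methoxyphenyl, so the same substituents at different numbered places do not give equivalent compounds. Nothing available accounts for this loss. Open, going by these compounds, is how an amine or a carboxylic acid in place of the methoxy group would read at this place.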